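The source may report more compounds than this note shows. Statements on the series, on what has been measured and on what is new or still open speak of the compounds shown alone.

Compound 3 `O=C(CSc1nnc(-c2ccncc2)o1)N/N=C/c1cc(Cl)cc(Cl)c1O` was tested in a functional assay on MCF7 cells (Homo sapiens) for cytotoxicity, read by MTT assay, with a stated time of 48 h (a higher number here means a weaker inhibitor, a lower number a stronger inhibitor), where compound 3 gives 5920 nM. Among the three measured compounds it sits second highest: compound 2 `O=C(CSc1nnc(-c2ccncc2)o1)N/N=C/c1cc(Cl)ccc1O` gives 5830 nM, and the step of a 1.0-fold higher number from compound 2 to compound 3 (0.01 log units; within the scatter) lies within the scatter, while compound 1 `O=C(CSc1nnc(-c2ccncc2)o1)N/N=C/c1ccccc1` gives 14600 nM, and the step of a 2.5-fold lower number from compound 1 to compound 3 (0.39 log units; beyond the scatter) is modest. Compound 4 `O=C(CSc1nnc(-c2ccncc2)o1)N/N=C/c1cc(Br)cc(Br)c1O` differs from compound 3 in one place: 3,5-dibromo-2-hydroxyphenyl in place of 3,5-dichloro-2-hydroxyphenyl on a carbon with a double bond to nitrogen. Within the data shown here, no measured step swaps one halogen for another; the nearest guide is the halogen-for-hydrogen step a 1.0-fold higher number from compound 2 to compound 3 (0.01 log units; within the scatter), which stayed within the scatter, and the step of a 2.5-fold lower number from compound 1 to compound 2 (0.40 log units; beyond the scatter) is of the same modest size as the step to compound 3. The expected step of a 1.2-fold lower number from compound 3 to compound 4 (0.07 log units; within the scatter) is therefore small. Compound 4 is estimated at 5000 nM, with a range from 2300 nM to 11000 nM.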

Compound 4, half-maximal inhibitory concentration: 9010 nM
The estimate for compound 4 lay 1.8-fold (0.26 log units) below the measured number; low and high end bracket the measured number.
By their numbers in this assay, from the lowest: compounds 2, 3, 4 and 1 (each within the scatter of the next, the first and the last beyond it).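

In this assay the change from chlorine to bromine at both places gives the step of a 1.5-fold higher number from compound 3 to compound 4 (0.18 log units; within the scatter) and the step of a 1.5-fold higher number from compound 2 to compound 4 (0.19 log units; within the scatter) also stays within the scatter, so compound 4 cannot be told apart from either chlorinated compound. Yet the step of a 1.6-fold lower number from compound 1 to compound 4 (0.21 log units; within the scatter) stays within the scatter too, so compound 4, unlike compound 2 and compound 3, is not clearly separated from the plain phenyl compound. Nothing available gives a reason for these steps. Open, on these data alone, is whether a methoxy group or an amine in place of the halogens would shift the number beyond the scatter.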